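The source may report more compounds than this note shows. Statements on the series, on what has been measured and on what is new or still open speak of the compounds shown alone.

Working notes on the series. All members share one core bearing a chlorinated benzyl arm and an aryl ring; some also carry a bromine. Compound 1 `O=[N+]([O-])c1ccc(-c2cn3nc(Cc4ccc(Cl)cc4)sc3n2)cc1` has a nitro group on the aryl ring and no bromine. In an ADME assay on CCRF-CEM cells (Homo sapiens) for cytotoxicity, with a stated time of 72 h (on this read-out higher numbers stand for weaker inhibition and lower numbers for stronger inhibition), compound 1 returns only the assay limit, > 250000 nM. Compound 2 `Fc1ccc(-c2nc3sc(Cc4ccc(Cl)cc4)nn3c2Br)cc1` carries the bromine and a fluorinated aryl ring. In this assay compound 2 likewise returns a limit, > 250000 nM. Compound 3 `Clc1ccc(Cc2nn3c(Br)c(-c4ccccc4)nc3s2)cc1` keeps the bromine with an unsubstituted aryl ring. In this assay compound 3 also sits at a limit, > 250000 nM. Going by the values given here, compound 3 thus stands where every value so far stands, at the limit of > 250000 nM in this assay, at which 3 of the 3 values shown sit, and the only single-point step recorded, a step that the two limits leave unreadable from compound 2 to compound 3, cannot be read. Compound 4 `O=[N+]([O-])c1ccc(-c2nc3sc(Cc4ccc(Cl)cc4)nn3c2Br)cc1` is reached from compound 3 by nitro in place of hydrogen on an aromatic carbon. Among the compounds with values here, no measured step bears on this change in readable form. Compound 1 carries the same nitro group and gives only a limit. Compound 4 is expected to give a limit as well, estimated at 300000 nM with a range from 100000 nM to 1000000 nM. This would mean an expected step that the limit leaves unreadable from compound 3 to compound 4, none beyond the scatter.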

Compound 4, half-maximal inhibitory concentration: 73000 nM
The estimate for compound 4 lay 4.1-fold (0.61 log units) above the measured number, outside the stated range (below it).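

In this assay, going by these compounds alone, nitro in place of hydrogen at this place on the aryl ring gives the first readable number, with an at least 3.4-fold lower number from compound 3 to compound 4 (0.53 log units; beyond the scatter). Nitro in place of fluoro at the same place gives an at least 3.4-fold lower number from compound 2 to compound 4 (0.53 log units; beyond the scatter), so among these three groups only nitro gives a readable number when the bromine is present. Nitro alone is not enough, as adding the bromine to the core gives an at least 3.4-fold lower number from compound 1 to compound 4 (0.53 log units; beyond the scatter), and only the combination in compound 4 leaves the limit shared by the other compounds: the limit of > 250000 nM in this assay, at which 3 of the 4 values shown sit.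

Going by these compounds, the step between the two compounds that both sit at the limit cannot be read, and the true size of each new step stays open. Also open, on these data alone, is whether an amine, a nitrile or a carboxylic acid at this place, or chlorine in place of the bromine, would give a readable number too.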